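This account rests on a few compounds, and the source may have more. Where it says the series, first, only, none or still open, it means among the compounds named here.

Compound 1 `O=C(N/N=C/c1ccc(-c2ccccc2)cc1)c1cnccn1` and compound 2 `O=C(N/N=C/c1ccc(O)cc1)c1cnccn1` share one core and differ only in what sits on the outer aromatic ring. In a functional assay on the whole organism (strain Swiss) for inhibition, with Mus musculus as the target, in the formalin test, with stated times of 40 min and 30 min, at a dose of 100 umol/kg by the oral route (on this read-out higher numbers stand for more inhibition at the one dose given (going by the name of the read-out) and lower numbers for less inhibition), compound 1 gives 46.9%, and compound 2 gives 16.7%. Within the data shown here, the one measured step, a number 30.2 percentage points lower from compound 1 to compound 2 (beyond the scatter), is the only guide available, and it places compound 2 at the lower of the two numbers recorded. The step to compound 3 `O=C(N/N=C/c1ccccc1)c1cnccn1` removes what was introduced there: hydrogen in place of hydroxy on an aromatic carbon. Since the swap from phenyl to hydroxy coincided with a large fall, taking the hydroxy away again is expected to recover part of that loss, though the data give no direct reading for an unsubstituted ring and the size is uncertain. The estimate for compound 3 is therefore 30%, within 10% to 50%, which would mean a step of a number 13.3 percentage points higher from compound 2 to compound 3 (beyond the scatter).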

Compound 3, a percentage reported as inhibition, in the whole organism at one dose (the size of the read-out at that dose, not a potency): 60.8%
Compound 3: middle estimate off by 30.8 percentage points, on the low side, outside the stated range (above it).
By their numbers in this assay, from the lowest: compound 2; then compound 1; then compound 3.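

In this assay, the hydrogen compound does not fall between the two substituted compounds but stands above both: taking away the hydroxy gives a number 44.1 percentage points higher from compound 2 to compound 3 (beyond the scatter) and is a larger change than replacing phenyl with hydrogen, which gives a number 13.9 percentage points higher from compound 1 to compound 3 (beyond the scatter) in this comparison. So neither group at this position on the ring is needed for the inhibition seen at this dose, and among the three compounds each substituent goes with less inhibition than hydrogen, hydroxy much more so than phenyl. Nothing available explains why these groups differ in this way.

Going by these compounds, whether a methoxy group, a chlorine atom or an amine at this position would also fall below hydrogen remains open. So does whether a hydroxy group elsewhere on the ring would cost as much.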